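This account rests on a few compounds, and the source may have more. Where it says the series, first, only, none or still open, it means among the compounds named here.

In a functional assay on MDA-MB-231 cells (Homo sapiens) for antiproliferative activity, with a stated time of 48 h (on this read-out higher numbers stand for weaker inhibition and lower numbers for stronger inhibition), compound 2 `CN1CCN(c2ccc(-c3cccc(C(F)(F)F)c3)nn2)CC1` stands at > 25000 nM as a limit and not a number. Compound 1 `CCN(CC)c1ccc(-c2cccc(C(F)(F)F)c2)nn1` also gives > 25000 nM as a limit. Compound 3 `FC(F)(F)c1cccc(-c2ccc(N3CCCC3)nn2)c1` differs from compound 2 by pyrrolidin-1-yl in place of 4-methylpiperazin-1-yl on an aromatic carbon with pyrrolidin-1-yl in place of 4-methylpiperazin-1-yl on an aromatic carbon. Among the compounds with values here, the one measured step bearing on this is a step that the two limits leave unreadable from compound 1 to compound 2 and its size cannot be read, so with the limit of > 25000 nM in this assay, at which 2 of the 2 values shown sit, as the only evidence, no step beyond the scatter is expected in this assay here. The expected step is a step that the limit leaves unreadable from compound 2 to compound 3 on this reasoning. Compound 3 is estimated at 30000 nM with an expected range from 15000 nM to 60000 nM and will most likely be reported as a limit again.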

Compound 3, half-maximal inhibitory concentration: > 25000 nM
Compound 3: a limit, no number; the forecaster's own chance of this, stated with the estimate: 85%; the middle value lies beyond the limit too.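

In this assay, within the data shown here, compound 3 is a limit and not a number, as are compound 1 and compound 2, so no step among them can be read. The compounds shown leave open whether these three differ at all in this assay.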